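Sulfonyl aryl swap: dichlorophenyl to phenyl, two cores

The source may report more compounds than this note shows. Statements on the series, on what has been measured and on what is new or still open speak of the compounds shown alone.

Measured so far:
compound 1 `O=C(c1ccccc1)c1ccc(NS(=O)(=O)c2ccc(Cl)cc2Cl)cc1`: 82%
compound 2 `O=C(c1ccccc1)c1cccc(NS(=O)(=O)c2ccc(Cl)cc2Cl)c1`: 69%
compound 3 `O=C(c1ccccc1)c1cccc(NS(=O)(=O)c2ccccc2)c1`: 4%

In an assay on CHO cells for binding affinity to integrin alpha-1 (Homo sapiens), read by WST assay, with a stated time of 2 h, tested at 50 uM (a higher number here means more inhibition at the concentration tested (going by the name of the read-out), a lower number less inhibition), compound 1 gives 82% and stands highest of the three. Compound 2 gives 69%. How the core of compound 1 differs from the core of compound 2 is not broken down here. The change phenyl in place of 2,4-dichlorophenyl on a sulfonyl sulfur produced the step of a number 65 percentage points lower from compound 2 to compound 3 (beyond the scatter), leaving compound 3 at 4%.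

Compound 4 `O=C(c1ccccc1)c1ccc(NS(=O)(=O)c2ccccc2)cc1` carries the same change on compound 1: phenyl in place of 2,4-dichlorophenyl on a sulfonyl sulfur. The place is the same in both cases, so this is the same change, seen once so far. For the measured compounds named here, a step of like size is expected, a number 64 percentage points lower from compound 1 to compound 4 (beyond the scatter), because a number 65 percentage points lower from compound 2 to compound 3 (beyond the scatter) is the only measure of this change available. Compound 4 is therefore estimated at 18%, with a range from 0% to 40%.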

Compound 4, a percentage reported as inhibition, at one concentration (the size of the read-out at that concentration, not a potency): 0%
Compound 4: the middle estimate sits 18 percentage points above what was measured; low and high end bracket the measured number.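

In this assay the swap to phenyl from 2,4-dichlorophenyl on the sulfonyl sulfur lowers the number on both cores, here with a number 82 percentage points lower from compound 1 to compound 4 (beyond the scatter), so the direction carries across these two pairs. The size of the step does not carry over unchanged: the same change on two cores in this assay, a number 65 percentage points lower (beyond the scatter) from compound 2 to compound 3 and a number 82 percentage points lower (beyond the scatter) from compound 1 to compound 4, 17 percentage points apart, beyond the scatter of two such steps. Two pairs cannot show why the steps differ, which of the two chlorine atoms matters, or whether the same holds on any further core.

Still open, on these data alone, is whether a phenyl with one chlorine keeps the number on either core. Also open, as far as these compounds go, is how other groups on that ring, such as methoxy or a carboxylic acid, behave in place of the chlorine atoms.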